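The compounds below may be only part of what the source reports. "The series", "measured", "known", "first", "only" and "open" are said of these compounds alone.

Of the compounds shown here, three built on a shared core have been measured in a functional assay on HepG2 cells (Homo sapiens) for antiproliferative activity, read by CCK-8 assay, with a stated time of 48 h; a lower number here means a stronger inhibitor, a higher number a weaker inhibitor. Compound 1 `CNC(=O)c1cc(Oc2ccc(/C=C/c3ccncc3)cc2)ccn1` gives 18200 nM in this assay. Compound 2 `O=C(Nc1ccccc1)c1cc(Oc2ccc(/C=C/c3ccncc3)cc2)ccn1` reaches only the limit of this assay, > 100000 nM. Compound 3 `O=C(NCc1ccc(F)cc1)c1cc(Oc2ccc(/C=C/c3ccncc3)cc2)ccn1` gives 37200 nM, the highest of the two numbers reported, set by a 2.0-fold higher number from compound 1 to compound 3 (0.31 log units; beyond the scatter) and an at least 2.6-fold lower number from compound 2 to compound 3 (0.42 log units; beyond the scatter). The unmeasured compound 4 `O=C(c1cc(Oc2ccc(/C=C/c3ccncc3)cc2)ccn1)N1CCCC1` differs from compound 3 by pyrrolidin-1-yl in place of (4-fluorobenzyl)amino on a carbonyl carbon. The changes at the amide nitrogen seen so far, an at least 5.4-fold higher number from compound 1 to compound 2 (0.73 log units; beyond the scatter) and a 2.0-fold higher number from compound 1 to compound 3 (0.31 log units; beyond the scatter), shift the number in both directions by modest amounts. A step of similar size, without a clear direction, is therefore expected, namely a 1.2-fold lower number from compound 3 to compound 4 (0.09 log units; within the scatter). Compound 4 is estimated at 30000 nM, with a range from 8000 nM to 120000 nM.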

Compound 4, half-maximal inhibitory concentration: 41600 nM
Compound 4: the middle estimate sits 1.4-fold (0.14 log units) below what was measured, and the stated range covers the measured number.
By their numbers in this assay, from the lowest: compound 1; then compounds 3 and 4 (each within the scatter of the next). At a limit, above all of these: compound 2.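

Among these compounds, with pyrrolidin-1-yl on the carbonyl carbon, the amide hydrogen present in the earlier compounds is gone, and the step stays within the scatter (a 1.1-fold higher number from compound 3 to compound 4 (0.05 log units; within the scatter)). This change from methylamino gives a modest step (a 2.3-fold higher number from compound 1 to compound 4 (0.36 log units; beyond the scatter)), while the change from anilino gives a lower number (an at least 2.4-fold lower number from compound 2 to compound 4 (0.38 log units; beyond the scatter)). That second step starts from a limit of the assay for compound 2, not a number: the limit of > 100000 nM in this assay, at which 1 of the 4 values shown sits.

On these data alone, whether morpholine or a carboxylic acid at the carbonyl carbon would fall below compound 1 remains open. A longer alkyl chain on the amide nitrogen is equally untested here.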